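A few compounds are considered here, and "the series" means these few. Any claim that something is new, unique, unknown or untested is made for them only; others in the source may bear on it.

In a functional assay on HL60/MX2 cells (Homo sapiens) for antiproliferative activity, read by MTT assay, with a stated time of 48 h (a higher number here means a weaker inhibitor, a lower number a stronger inhibitor), compound 2 `CN(C)CCCn1c(N)c(-c2nc3ccccc3[nH]2)c2nc(C#N)c(C#N)nc21` gives 2390 nM and compound 3 `CN1CCN(CCCn2c(N)c(-c3nc4ccccc4[nH]3)c3nc(C#N)c(C#N)nc32)CC1` gives 3320 nM, so compound 3 stands level with compound 2 within the scatter. Compound 1 `N#Cc1nc2c(-c3nc4ccccc4[nH]3)c(N)n(CCN3CCCC3)c2nc1C#N` is reported only as a limit, > 50000 nM. Compound 4 `N#Cc1nc2c(-c3nc4ccccc4[nH]3)c(N)n(CCCO)c2nc1C#N` carries hydroxy in place of 4-methylpiperazin-1-yl on a saturated chain carbon, three bonds along the chain from an aromatic nitrogen. For the measured compounds named here, no measured step makes this exact change. The closest one, at the same place, was small: a 1.4-fold higher number from compound 2 to compound 3 (0.14 log units; within the scatter). Two changes on the same chain were large, an at least 20-fold lower number from compound 1 to compound 2 (1.32 log units; beyond the scatter) and an at least 15-fold lower number from compound 1 to compound 3 (1.17 log units; beyond the scatter), so this part of the molecule can matter in this assay. A moderate move toward weaker inhibition is therefore expected, a 2.7-fold higher number from compound 3 to compound 4 (0.43 log units; beyond the scatter). For compound 4 the estimated value is 9000 nM, with an expected range of 2500 nM to 35000 nM.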

Compound 4, half-maximal inhibitory concentration: > 50000 nM
Compound 4: no number, only a limit (the forecaster's own chance of this, stated with the estimate: 15%); middle value at least 5.5-fold (0.74 log units) from the limit.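

In this assay, replacing the amine at the end of the propyl chain with hydroxy costs far more than exchanging one amine for another, giving an at least 15-fold higher number from compound 3 to compound 4 (1.17 log units; beyond the scatter) and an at least 20-fold higher number from compound 2 to compound 4 (1.32 log units; beyond the scatter). Among the propyl compounds, activity is seen only with an amine at the chain end. An amine alone is not enough, however, as compound 1 carries pyrrolidin-1-yl on a shorter chain and is also reported only as a limit: the limit of > 50000 nM in this assay, at which 2 of the 4 values shown sit.

The step between compound 1 and compound 4 cannot be read, since both are limits. As far as these compounds go, whether pyrrolidin-1-yl on the propyl chain, a primary amine or a carboxylic acid would retain activity remains open.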